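The source may hold more compounds than are shown below. What is called first, only, known or untested is meant among the compounds shown, and "the series" means these compounds.

Two compounds have been measured so far in a functional assay with Homo sapiens as the target (on this read-out lower numbers stand for stronger inhibition and higher numbers for weaker inhibition), so far:

- compound 1 `CC(C)[C@H](NC(=O)COc1cccc2ccccc12)C(=O)N[C@@H](CC(=O)O)C(=O)COc1cc(F)ccc1F` gives 19700 nM
- compound 2 `CC(C)[C@H](NC(=O)COc1cccc2ccccc12)C(=O)N[C@@H](CC(=O)O)C(=O)COc1cc(F)c(F)cc1F` gives 16700 nM

Compound 2 stands level with compound 1, as the gap between them (a 1.2-fold lower number from compound 1 to compound 2 (0.07 log units; within the scatter)) is no larger than the normal scatter of repeat measurements. Compound 3 `CC(C)[C@H](NC(=O)COc1cccc2ccccc12)C(=O)N[C@@H](CC(=O)O)C(=O)COc1c(F)c(F)c(F)c(F)c1F` differs from compound 2 by one change (2,3,4,5,6-pentafluorophenyl in place of 2,4,5-trifluorophenyl on an oxygen on a saturated carbon): 2,3,4,5,6-pentafluorophenyl in place of 2,4,5-trifluorophenyl on an oxygen on a saturated carbon. Going by the values given here, the only measured step that bears on this is the one to compound 2 (a 1.2-fold lower number from compound 1 to compound 2 (0.07 log units; within the scatter)), which also put fluoro in place of hydrogen on an aromatic carbon and changed nothing beyond the scatter. A similarly small step is therefore expected, with no clear direction (a 1.1-fold lower number from compound 2 to compound 3 (0.05 log units; within the scatter)). Compound 3 is estimated at 15000 nM (expected range 6000 nM to 38000 nM).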

Compound 3, half-maximal inhibitory concentration: 8890 nM
The estimate for compound 3 lay 1.7-fold (0.23 log units) above the measured number; measured number inside the range.
By their numbers in this assay, from the lowest: compounds 3, 2 and 1 (each within the scatter of the next, the first and the last beyond it).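

In this assay the step of a 1.9-fold lower number from compound 2 to compound 3 (0.27 log units; within the scatter) stays small, but the step of a 2.2-fold lower number from compound 1 to compound 3 (0.35 log units; beyond the scatter) is the first among these compounds to pass the scatter, if only modestly. At this position on the oxygen, then, 2,3,4,5,6-pentafluorophenyl in place of 2,5-difluorophenyl separates two compounds, while 2,3,4,5,6-pentafluorophenyl in place of 2,4,5-trifluorophenyl does not. No supporting measurement is available to explain the difference. Still open, going by these compounds, is how a plain phenyl ring, or a phenyl ring carrying an amine or a carboxylic acid, would compare at this position.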